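A few compounds are considered here, and "the series" means these few. Any claim that something is new, unique, unknown or untested is made for them only; others in the source may bear on it.

Compound 1 `COC(=O)[C@@H]1N=C(SC(C)C)[C@H]2C(=O)N(c3ccccc3)C(=O)[C@H]21` gives 89% in a functional assay for inhibition, tested at 100 uM; a lower number here means less inhibition, a higher number more inhibition at the concentration tested (going by the name of the read-out). Compound 2 `COC(=O)[C@H]1N=C(SC)[C@H]2C(=O)N(c3ccccc3)C(=O)[C@H]21` gives 84%.

Of the two numbers in this assay, compound 2 gives the smaller, but compound 1 sits within the scatter of it, so the two cannot be told apart. Compound 3 `COC(=O)[C@@H]1N=C(SC)[C@H]2C(=O)N(c3ccccc3)C(=O)[C@H]21` awaits measurement. It differs from compound 2 in one respect: the two compounds have the same atoms and bonds and differ only in configuration as drawn: 1 of 3 stereo elements differ; a stereocentre at a saturated ring carbon is drawn S in compound 2 and R in compound 3. For the measured compounds named here, no measured pair separates a change of configuration from other changes, so there is no measured guide for this move. The step of a number 1 percentage points lower from compound 2 to compound 3 (within the scatter) is expected to be small, in no particular direction. Compound 3 is estimated at 83%, in the range 65% to 93%.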

Compound 3, a percentage reported as inhibition, at one concentration (the size of the read-out at that concentration, not a potency): 93%
Beside the measured number, compound 3's estimate is 10 percentage points below it, within the range that was stated.
By their numbers in this assay, from the lowest: compounds 2, 1 and 3 (each within the scatter of the next).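

For the compounds shown here, the pair gives the first direct reading of this stereocentre at a saturated ring carbon. In this assay, drawing it R rather than S gives a number 9 percentage points higher from compound 2 to compound 3 (within the scatter), so configuration at this position has no effect that can be told from the scatter. This pair isolates that one change: the fact that compounds 2 and 3 differ only in the configuration as drawn

Methyl in place of isopropyl on a sulfur gives a number 4 percentage points higher from compound 1 to compound 3 (within the scatter), likewise unresolved. Still open, as far as these compounds go, is whether a longer chain or an amine on that sulfur would shift the number, and whether these compounds would separate at lower concentrations.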